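A few compounds are considered here, and "the series" means these few. Any claim that something is new, unique, unknown or untested is made for them only; others in the source may bear on it.

In a functional assay on HT-29 cells (Homo sapiens) for antiproliferative activity, read by sulforhodamine B assay, with a stated time of 48 h (on this read-out higher numbers stand for weaker inhibition of growth and lower numbers for stronger inhibition of growth), compound 2, with the structure `COc1ccc2c(c1)C(=O)OC(CCCO)C2`, gives 132 ug/mL. Going by the values given here, that is the only plain number in this set; compound 1, with the structure `COc1ccc2c(c1)C(=O)OC(CO)C2`, gives only a limit in this assay, namely >= 250 ug/mL. Among the compounds with values here, the one measured step is an at least 1.8-fold lower number from compound 1 to compound 2 (0.27 log units; that floor lies within the scatter), with the change 2-hydroxyethyl in place of hydroxy on a saturated chain carbon bound to a saturated ring carbon; it rests on a limit, (the limit of >= 250 ug/mL in this assay, at which 1 of the 2 values shown sits), so its size is uncertain. Compound 3, with the structure `CCCCCOCCCC1Cc2ccc(OC)cc2C(=O)O1`, differs from compound 2 by pentyl in place of hydrogen on an oxygen on a saturated carbon. Within the data shown here, no measured step touches an oxygen in this way, so the one step lends only a faint hint that lengthening at this end gives a lower number. Compound 3 is therefore expected to give about 70 ug/mL in this assay, within a wide range from 20 ug/mL to 250 ug/mL, which amounts to an expected step of a 1.9-fold lower number from compound 2 to compound 3 (0.28 log units; within the scatter).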

Compound 3, concentration for 50% growth inhibition: 43.5 ug/mL
For compound 3 the middle estimate is 1.6-fold (0.21 log units) above the measured one, and the stated range covers the measured number.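

In this assay, going by these compounds alone, pentyl in place of hydrogen on an oxygen on a saturated carbon gives a 3.0-fold lower number from compound 2 to compound 3 (0.48 log units; beyond the scatter), the first step in this set that is printed as beyond the scatter. This position therefore accepts the change from hydroxy to pentyloxy without loss of growth inhibition, and the hydrogen on this oxygen is not needed for the activity seen in compound 3. Compound 1 still offers no firm size for a comparison of steps, because its value is a limit: the limit of >= 250 ug/mL in this assay, at which 1 of the 3 values shown sits.

On these data alone, whether methyl or ethyl in place of pentyl, or a longer chain such as octyl, would move the number further remains open. Also open, as far as these compounds go, is whether a group carrying an amine or a carboxylic acid in place of pentyl would give a similar number.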